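Shortening the Chain on an Acylguanidine Histamine Agonist

The compounds below may be only part of what the source reports. "The series", "measured", "known", "first", "only" and "open" are said of these compounds alone.

Measured compounds:
- compound 1 `Cc1ccc(CC(C)CNC(=O)/N=C(\N)NCCCc2sc(N)nc2C)cc1` gives 0.68
- compound 2 `CCCCCCNC(=O)/N=C(\N)NCCCc1sc(N)nc1C` gives 0.6

Both were tested in a functional assay on membranes from Sf9 cells for agonist activity at histamine H2 receptor (Homo sapiens), read by scintillation counting and GTPgammaS binding, with a stated time of 90 min; a higher number here means a larger maximal response, a lower number a smaller maximal response. Compound 2 has the lower of the two numbers; the nearest value, from compound 1, sits within the scatter of it, so the two cannot be told apart. Compound 3 `CCCNC(=O)/N=C(\N)NCCCc1sc(N)nc1C` has not yet been measured. Its difference from compound 2 is hydrogen in place of propyl on a saturated chain carbon, three bonds along the chain from an amide-type nitrogen. Going by the values given here, with no measured step of this kind to lean on, a small change is expected, if any: compound 3 is estimated to give 0.55 (range 0.35 to 0.75), a step of a number 0.050 lower from compound 2 to compound 3 (within the scatter) that is expected to stay near the scatter.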

Compound 3, intrinsic activity: the largest response reached, as a fraction of the reference agonist's: 0.79
The estimate for compound 3 lay 0.24 below the measured number; measured number above the stated range.
By their numbers in this assay, from the lowest: compounds 2 and 1 (each within the scatter of the next); then compound 3.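

Shortening hexyl to propyl raises the maximal response in this position (a number 0.19 higher from compound 2 to compound 3 (beyond the scatter)) in this assay, and the same holds for the change from the 4-methylbenzyl-bearing chain of compound 1 (a number 0.11 higher from compound 1 to compound 3 (beyond the scatter)). This chain end therefore does affect the response, and the short propyl chain of compound 3 gives the largest response of the three, by a modest margin. Nothing measured here explains the rise. Going by these compounds, whether an ethyl or butyl chain would give a larger or smaller response remains open, as does the effect of an amine at the end of the chain.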